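From a Urea to a Carbamate on a Shared Core

The compounds below may be only part of what the source reports. "The series", "measured", "known", "first", "only" and "open" are said of these compounds alone.

Compound 2 `CN(C)C(=O)Nc1cccc(-c2ccc(N(C)C)cc2)c1` stands highest of the two numbers measured in an assay on COS-7 cells for inhibition of patatin-like phospholipase domain-containing protein 2 (Mus musculus), tested at 200 uM (a higher number here means more inhibition at the concentration tested (going by the name of the read-out), a lower number less inhibition), where compound 2 gives 98%; compound 1 `CCOC(=O)c1cccc(-c2ccc(N(C)C)cc2)c1` gives 87%. Going by the values given here, the only measured step, a number 11 percentage points higher from compound 1 to compound 2 (beyond the scatter), concerns a different change. Compound 3 `CC(C)COC(=O)Nc1cccc(-c2ccc(N(C)C)cc2)c1` differs from compound 2 by isobutoxy in place of dimethylamino on a carbonyl carbon. Among the compounds with values here, no measured step bears directly on this change, so compound 3 is expected to stay close to compound 2, with a step of a number 6 percentage points lower from compound 2 to compound 3 (within the scatter) that may fall within the scatter. Compound 3 is therefore estimated at 92%, between 78% and 100%.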

Compound 3, a percentage reported as inhibition, at one concentration (the size of the read-out at that concentration, not a potency): 90%
Estimate against measurement, compound 3: 2 percentage points above; measured number inside the range.
By their numbers in this assay, from the lowest: compounds 1, 3 and 2 (each within the scatter of the next, the first and the last beyond it).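

Putting isobutoxy in place of dimethylamino on the carbonyl carbon, which turns the urea into a carbamate, gives a number 8 percentage points lower from compound 2 to compound 3 (within the scatter) in this assay. On this shared core, then, the read-out does not separate the two groups, even though isobutoxy is the larger group and joins through oxygen rather than nitrogen. No measurement here offers an explanation for this result. Still open, from the compounds shown here alone, is how a much shorter group such as methoxy, or a morpholine ring, would read on the same carbonyl carbon. A single tested concentration also leaves the potencies of compound 2 and compound 3 unknown.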